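Acetyl for Methoxy on the Fused Ring of Compound 3

The source may hold more compounds than are shown below. What is called first, only, known or untested is meant among the compounds shown, and "the series" means these compounds.

Of the compounds shown here, three have been tested in a functional assay on HEK293 cells for agonist activity at Free fatty acid receptor 1 (Homo sapiens), read by fluorescence and calcium flux, with a stated time of 10 min; on this read-out lower numbers stand for an effect already at smaller amounts and higher numbers for an effect only at larger amounts of compound. Compound 1 `O=C(O)CCc1ccc(OCC2COc3ccc(Cl)cc3O2)cc1F` gives 830 nM, and compound 2 `O=C(O)CCc1ccc(OCC2COc3cc(Br)ccc3O2)cc1F` gives 980 nM. Compound 3 `CC#C[C@@H](CC(=O)O)c1ccc(OC[C@H]2COc3ccc(OC)cc3O2)cc1`, which carries a methoxy on its fused ring system and a different acid-bearing side chain, gives 130 nM, the lowest number of the three; its gaps to compound 1 and to compound 2 both lie beyond the usual scatter of this assay.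

Compound 4 `CC#C[C@@H](CC(=O)O)c1ccc(OC[C@H]2COc3ccc(C(C)=O)cc3O2)cc1` has not yet been measured. It differs from compound 3 in one place: acetyl in place of methoxy on an aromatic carbon. Going by the values given here, no pair of measured compounds shows this kind of exchange, so its size in this assay cannot be read from the data. Because compound 3 already stands at 130 nM, compound 4 is expected to stay close to it, with a step from compound 3 to compound 4 of a 1.5-fold higher number from compound 3 to compound 4 (0.19 log units; within the scatter), which may well remain within the scatter. The estimate for compound 4 in this assay is therefore 200 nM, with a range from 60 nM to 650 nM.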

Compound 4, half-maximal effective concentration: > 30000 nM
Compound 4 gave a limit, no number; the forecaster's own chance of this, stated with the estimate: 3%; middle value at least 150-fold (2.17 log units) from the limit.
By their numbers in this assay, from the lowest: compound 3; then compounds 1 and 2 (each within the scatter of the next). At a limit, above all of these: compound 4.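

In this assay, acetyl in place of methoxy on this aromatic carbon gives an at least 230-fold higher number from compound 3 to compound 4 (2.36 log units; beyond the scatter), so this one exchange is enough to take the compound from the lowest number shown to beyond the assay's limit. The result for compound 4 is a limit, not a number: the limit of > 30000 nM in this assay, at which 1 of the 4 values shown sits. Going by these compounds alone, the two groups have the same counts of hydrogen-bond donors and acceptors and neither has a net charge, so those counts do not separate this pair, and the earlier compounds held no exchange at this position that could show how much it matters.

From the compounds shown here alone, it remains open whether other groups on this carbon, such as an ethyl, a hydroxyl or an amide, stay close to compound 3 or fall away as compound 4 does. Also open, going by these compounds, is whether the same exchange would act alike on the core of compound 1, with its different acid-bearing side chain.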